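Methyl on a phenolic oxygen across two stilbene-type cores

The compounds below may be only part of what the source reports. "The series", "measured", "known", "first", "only" and "open" are said of these compounds alone.

Three stilbene diols and ethers have been measured in a functional assay on HT-29 cells (Homo sapiens) for inhibition, read by MTT assay, with a stated time of 2 days; on this read-out lower numbers stand for stronger inhibition and higher numbers for weaker inhibition. Compound 1 `Oc1ccccc1/C=C/c1ccccc1O` gives 25 ug/mL. Compound 2 `Oc1ccc(/C=C/c2ccccc2O)cc1` gives 22 ug/mL; the difference between the two cores is not broken down here. Compound 3 `COc1ccccc1/C=C/c1ccccc1O` gives 23 ug/mL, and the change from compound 1 to compound 3, (methyl in place of hydrogen on an oxygen on an aromatic ring), made a step of a 1.1-fold lower number from compound 1 to compound 3 (0.04 log units; within the scatter). Compound 4 `COc1ccc(/C=C/c2ccccc2O)cc1`, still to be measured in this assay, carries the same change, (methyl in place of hydrogen on an oxygen on an aromatic ring), on the core of compound 2. Because a 1.1-fold lower number from compound 1 to compound 3 (0.04 log units; within the scatter) stayed within the scatter, the step is expected to be about a 1.0-fold lower number from compound 2 to compound 4 (0.02 log units; within the scatter). For compound 4 the estimated value in this assay is 21 ug/mL, most likely between 11 ug/mL and 42 ug/mL, since all three measured values lie close together.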

Compound 4, half-maximal inhibitory concentration: 10 ug/mL
For compound 4 the middle estimate is 2.1-fold (0.32 log units) above the measured one, outside the stated range (below it).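

In this assay the change from hydroxy to methoxy gives a 2.2-fold lower number from compound 2 to compound 4 (0.34 log units; beyond the scatter) and so a modest move towards stronger inhibition on this core. On the core of compound 1 the same change stayed within the scatter, yet the two steps cannot be told apart: the same change on two cores in this assay, a 1.1-fold lower number (0.04 log units; within the scatter) from compound 1 to compound 3 and a 2.2-fold lower number (0.34 log units; beyond the scatter) from compound 2 to compound 4, 2.0-fold (0.31 log units) apart, within the scatter of two such steps. The data therefore do not show that the core alters the effect of the change, and two pairs are too few to show that the effect carries over reliably to other cores.

The compounds shown leave open what a longer chain on that oxygen, such as ethyl or propyl, would do. They also leave open how an amine in place of the hydroxy would read.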